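From a Methoxyphenyl to a Methylphenyl Group

The source may report more compounds than this note shows. Statements on the series, on what has been measured and on what is new or still open speak of the compounds shown alone.

Three compounds have so far been measured in an assay on isolated protein for inhibition of 15-hydroxyprostaglandin dehydrogenase [NAD(+)] (Homo sapiens), read by fluorescence, with a stated time of 15 min; on this read-out lower numbers stand for stronger inhibition and higher numbers for weaker inhibition:

compound 1 `O=C(c1ccc2c(c1)ncn2-c1ccccc1)N1CCCCC1`: 22 nM
compound 2 `COc1cccc(-n2cnc3cc(C(=O)N4CCCCC4)ccc32)c1`: 19 nM
compound 3 `CC(C)(C)c1cccc(-n2cnc3cc(C(=O)N4CCCCC4)ccc32)c1`: 171 nM

Compound 2 sits at the strong end of the numbers shown, side by side with compound 1: the step of a 1.2-fold lower number from compound 1 to compound 2 (0.06 log units; within the scatter) lies within the scatter, so the two cannot be told apart. Compound 3 is clearly weaker, as the step of a 9.0-fold higher number from compound 2 to compound 3 (0.95 log units; beyond the scatter) shows.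

Compound 4 `Cc1ccc(-n2cnc3cc(C(=O)N4CCCCC4)ccc32)cc1` has not been measured. Compared with compound 2 the change is 4-methylphenyl in place of 3-methoxyphenyl on an aromatic nitrogen. The measured steps that bear on it all alter the same ring attached to the ring nitrogen: a 1.2-fold lower number from compound 1 to compound 2 (0.06 log units; within the scatter) is within the scatter, while a 7.8-fold higher number from compound 1 to compound 3 (0.89 log units; beyond the scatter) and a 9.0-fold higher number from compound 2 to compound 3 (0.95 log units; beyond the scatter) are modest losses. Among the measured compounds shown here, a methyl group is smaller than tert-butyl, but no measured compound carries a group in the place where 4-methylphenyl carries it, so the data give no direct guide. A small step is expected, most likely a slight weakening. The expected result in this assay is the step of a 1.8-fold higher number from compound 2 to compound 4 (0.27 log units; within the scatter). The estimate for compound 4 is 35 nM, with a range from 12 nM to 100 nM.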

Compound 4, half-maximal inhibitory concentration: 19 nM
For compound 4 the middle estimate is 1.8-fold (0.27 log units) above the measured one; the measured number falls inside the stated range.
By their numbers in this assay, from the lowest: compounds 2, 4 and 1 (each within the scatter of the next); then compound 3.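

In this assay, 4-methylphenyl can take the place of 3-methoxyphenyl on the aromatic nitrogen with no visible cost (no change at the digits printed from compound 2 to compound 4 (within the scatter)), even though the swap changes both the group on the ring and where it sits. Compared with the plain phenyl ring of compound 1, adding the methyl group also leaves the result within the scatter (a 1.2-fold lower number from compound 1 to compound 4 (0.06 log units; within the scatter)), so this ring accepts a small group in a second place, and the only clear loss shown remains the one that comes with tert-butyl (a 7.8-fold higher number from compound 1 to compound 3 (0.89 log units; beyond the scatter)). No measurement at hand explains why these different groups give such similar numbers.

The compounds shown leave open how much larger the group in the place of this methyl can become, for instance whether ethyl, a longer chain or tert-butyl would keep the number or lose it. They also leave open how this ring would respond to a group of a different kind, such as an amine or a carboxylic acid, in either of the places tried so far.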